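The source may hold more compounds than are shown below. What is called first, only, known or untested is meant among the compounds shown, and "the series" means these compounds.

Three measured compounds share one core and differ only in the group on the aromatic ring: compound 1 `CC[C@@H](CCn1cncn1)c1ccccc1`, compound 2 `CC[C@@H](CCn1cncn1)c1ccc(F)cc1` and compound 3 `CC[C@@H](CCn1cncn1)c1ccc(C)cc1`. In an ADME assay on HEp-2 cells (Homo sapiens) for cytotoxicity, read by MTT assay, with a stated time of 3 days (on this read-out lower numbers stand for higher toxicity in this test and higher numbers for lower toxicity in this test), compound 1 gives 89.9 ug/mL, compound 2 gives 90.3 ug/mL and compound 3 gives 69.9 ug/mL. Compound 3 sits close to both, since a 1.3-fold lower number from compound 1 to compound 3 (0.11 log units; within the scatter) and a 1.3-fold lower number from compound 2 to compound 3 (0.11 log units; within the scatter) stay inside the scatter, as does a 1.0-fold higher number from compound 1 to compound 2 (0.00 log units; within the scatter). Compound 4 `CC[C@@H](CCn1cncn1)c1ccc(OC)cc1` carries methoxy in place of methyl on an aromatic carbon. All three earlier swaps at this ring position left the numbers essentially unchanged, so for compound 4 an estimated step of a 1.1-fold higher number from compound 3 to compound 4 (0.03 log units; within the scatter) is expected, not beyond the scatter. Compound 4 is therefore estimated at 75 ug/mL, expected to lie between 40 ug/mL and 150 ug/mL.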

Compound 4, half-maximal cytotoxic concentration: 146 ug/mL
For compound 4 the middle estimate is 1.9-fold (0.29 log units) below the measured one, and the stated range covers the measured number.
By their numbers in this assay, from the lowest: compounds 3, 1, 2 and 4 (each within the scatter of the next, the first and the last beyond it).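

Going by these compounds alone, at this ring position, para to a large group, methoxy in place of methyl gives the first step beyond the scatter in this assay (a 2.1-fold higher number from compound 3 to compound 4 (0.32 log units; beyond the scatter)), though only a modest one. Methoxy in place of fluoro (a 1.6-fold higher number from compound 2 to compound 4 (0.21 log units; within the scatter)) and in place of hydrogen (a 1.6-fold higher number from compound 1 to compound 4 (0.21 log units; within the scatter)) both stay within the scatter, so only the comparison with methyl separates clearly. No evidence is available to explain this step. From the compounds shown here alone, whether an amine or a longer chain such as ethoxy at this position would move the number further remains open.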